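This account rests on a few compounds, and the source may have more. Where it says the series, first, only, none or still open, it means among the compounds named here.

Measured so far:
compound 1 `O=c1[nH]cnc2c1c(-c1ccsc1)cn2[C@@H]1O[C@H](CO)[C@@H](O)[C@H]1O` — > 20000 nM
compound 2 `Nc1nc2c(c(-c3ccccc3)cn2[C@@H]2O[C@H](CO)[C@@H](O)[C@H]2O)c(=O)[nH]1` — > 20000 nM

In a functional assay on HeLa S3 cells (Homo sapiens) for antiproliferative activity, read by XTT assay, with a stated time of 72 h (on this read-out lower numbers stand for stronger inhibition and higher numbers for weaker inhibition), compound 1 gives > 20000 nM, which is a limit of the assay and not a number. In this assay compound 2 gives > 20000 nM, again a limit. Going by the values given here, compound 2 therefore stands at the limit together with the only other value shown; nothing separates the two. Compound 3 `Nc1nc2c(c(-c3ccsc3)cn2[C@@H]2O[C@H](CO)[C@@H](O)[C@H]2O)c(=O)[nH]1` has not been measured in this assay. It differs from compound 2 by thiophen-3-yl in place of phenyl on an aromatic carbon. The same thiophen-3-yl already sits on compound 1, which also reaches only the limit. Among the compounds with values here, no step between measured compounds exists, so the size of this step can only be expected: no change beyond the scatter, in either direction, given (the limit of > 20000 nM in this assay, at which 2 of the 2 values shown sit). The estimate for compound 3 in this assay is 40000 nM, with a range of 10000 nM to 150000 nM, most likely reported as a limit once more. The expected step is a step that the limit leaves unreadable from compound 2 to compound 3.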

Compound 3, half-maximal inhibitory concentration: > 20000 nM
Compound 3: no number, only a limit (the forecaster's own chance of this, stated with the estimate: 85%); the middle value lies beyond the limit too.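

In this assay compound 3 gives > 20000 nM, a limit and not a number. No step among compound 1, compound 2 and compound 3 can be read: the limit of > 20000 nM in this assay, at which 3 of the 3 values shown sit.

Still open, on these data alone, is how far thiophen-3-yl in place of phenyl, or amino in place of hydrogen, moves the read-out in this assay.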